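The compounds below may be only part of what the source reports. "The series", "measured", "known", "first", "only" and "open" are said of these compounds alone.

Compound 2 `CC1CC(C)CN(c2nc(Nc3ccc(C#N)c(C(F)(F)F)c3)nc(Oc3ccnc4ccccc34)n2)C1` carries a 3,5-dimethylpiperidin-1-yl group on the shared core. In a functional assay on DU-145 cells (Homo sapiens) for cytotoxicity, read by sulforhodamine B assay, with a stated time of 48 h (a lower number here means that less compound is tolerated, a higher number that more compound is tolerated), compound 2 reaches only the limit of the measurement, > 100000 nM. Compound 1 `CC(=O)N1CCN(c2nc(Nc3ccc(C#N)c(C(F)(F)F)c3)nc(Oc3ccnc4ccccc34)n2)CC1` bears a 4-acetylpiperazin-1-yl group on the same core; in this assay compound 1 likewise gives only the limit > 100000 nM. The step that the two limits leave unreadable from compound 1 to compound 2 therefore cannot be read, since (the limit of > 100000 nM in this assay, at which 2 of the 2 values shown sit). Compound 3 `N#Cc1ccc(Nc2nc(Oc3ccnc4ccccc34)nc(N3CCN(c4ccccn4)CC3)n2)cc1C(F)(F)F` differs from compound 2 in one place: 4-(pyridin-2-yl)piperazin-1-yl in place of 3,5-dimethylpiperidin-1-yl on an aromatic carbon. For the measured compounds named here, the only measured step that bears on this position is a step that the two limits leave unreadable from compound 1 to compound 2, whose size is not readable, so neither a direction nor a size can be taken from it. The expected step is a number no higher from compound 2 to compound 3 (the limit leaves the size open), which is estimated to stay within the scatter. Compound 3 is therefore expected to give 100000 nM in this assay, with a range from 30000 nM to 300000 nM.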

Compound 3, concentration lethal to 50% of the cells: > 100000 nM
Compound 3: only a limit was reported; the forecaster's own chance of this, stated with the estimate: 80%; the middle value sits exactly at the limit.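

For the compounds shown here, compound 1, compound 2 and compound 3 all stop at a limit in this assay, so no step among them can be read: the limit of > 100000 nM in this assay, at which 3 of the 3 values shown sit. The compounds shown leave open whether the three groups on the shared core differ at all in this assay, and in which direction.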